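The compounds below may be only part of what the source reports. "The series", "measured", "known", "first", "only" and "open" are said of these compounds alone.

Compounds measured in an assay on isolated protein for inhibition of Caspase-8 (Homo sapiens); on this read-out lower numbers stand for stronger inhibition and higher numbers for weaker inhibition:
compound 1, `O=C(CN1CC=CC[C@H](NC(=O)c2cc(Cl)ccc2Cl)C1=O)N[C@H]1CC(=O)OC1O`, 554 nM
compound 2, `O=C(CN1CC=CC[C@H](NC(=O)c2cc3ccccc3s2)C1=O)N[C@H]1CC(=O)OC1O`, 1450 nM
compound 3, `CC1=CC[C@H](NC(=O)c2ccc3ccccc3c2)C(=O)N(CC(=O)N[C@H]2CC(=O)OC2O)C1`, 2690 nM

Compound 3 has the highest number of the three. Its gap to compound 2 lies within the scatter, so no order between these two can be claimed; its gap to compound 1 lies beyond the scatter. Compound 4, `O=C(CN1CC=CC[C@H](NC(=O)c2ccc3ccccc3c2)C1=O)N[C@H]1CC(=O)OC1O`, differs from compound 3 by hydrogen in place of methyl on a double-bonded ring carbon. The only step measured among these compounds is a 2.6-fold higher number from compound 1 to compound 2 (0.42 log units; beyond the scatter), which concerns the group on the carbonyl carbon and says nothing about the seven-membered ring. Within the data shown here, no measured step bears on the present change. On that basis the change from compound 3 to compound 4 is expected to give no step beyond the scatter in this assay, a 1.3-fold lower number from compound 3 to compound 4 (0.13 log units; within the scatter). Compound 4 is accordingly expected to give about 2000 nM in this assay, with a range from 700 nM to 6000 nM.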

Compound 4, half-maximal inhibitory concentration: 2160 nM
The estimate for compound 4 lay 1.1-fold (0.03 log units) below the measured number, and the stated range covers the measured number.
By their numbers in this assay, from the lowest: compound 1; then compounds 2, 4 and 3 (each within the scatter of the next).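

In this assay, among these compounds, hydrogen in place of methyl on the double-bonded ring carbon gives a 1.2-fold lower number from compound 3 to compound 4 (0.10 log units; within the scatter) and so leaves no step that can be told from the scatter at this position, two ring bonds from the ring nitrogen, with naphthalen-2-yl on the carbonyl carbon. With hydrogen at that ring carbon, the naphthalen-2-yl group can also be set against the other carbonyl substituents: a 1.5-fold higher number from compound 2 to compound 4 (0.17 log units; within the scatter) does not separate it from 1-benzothiophen-2-yl, while a 3.9-fold higher number from compound 1 to compound 4 (0.59 log units; beyond the scatter) does separate it from 2,5-dichlorophenyl. No evidence is available that would explain these results.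

Going by these compounds, whether an ethyl, hydroxymethyl or aminomethyl group on this ring carbon would match methyl remains open. Also open, on these data alone, is whether methyl and hydrogen would stay this close with 2,5-dichlorophenyl on the carbonyl carbon.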